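Methylating the amine nitrogen of compound 3

This account rests on a few compounds, and the source may have more. Where it says the series, first, only, none or still open, it means among the compounds named here.

Measured so far in an ADME assay on MT4 cells (Homo sapiens) for cytotoxicity, read by MTT assay, with a stated time of 4 days; on this read-out lower numbers stand for higher toxicity in this test and higher numbers for lower toxicity in this test:
compound 1 `Cc1cc(C)cc(Cn2c(=O)cc(NC3CC3)n(Cc3ccccc3)c2=O)c1`: > 100000 nM
compound 2 `Cc1cc(C)cc(Cn2c(=O)cc(N3CCNCC3)n(Cc3ccccc3)c2=O)c1`: 16000 nM
compound 3 `CNc1cc(=O)n(Cc2cc(C)cc(C)c2)c(=O)n1Cc1ccccc1`: 65000 nM

The value for compound 1 is a limit of this assay, not a number, as the limit of > 100000 nM in this assay, at which 1 of the 3 values shown sits, records. Among the two numbers, compound 3 gives the highest, with compound 2 nearest: a 4.1-fold higher number from compound 2 to compound 3 (0.61 log units; beyond the scatter). Compound 1 to compound 2 showed the larger movement, an at least 6.2-fold lower number from compound 1 to compound 2 (0.79 log units; beyond the scatter), whereas an at least 1.5-fold lower number from compound 1 to compound 3 (0.18 log units; that floor lies within the scatter) stayed within the scatter.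

Compound 4 `Cc1cc(C)cc(Cn2c(=O)cc(N(C)C)n(Cc3ccccc3)c2=O)c1` carries methyl in place of hydrogen on a nitrogen on an aromatic ring. Among the compounds with values here, only one measured step touches this nitrogen, the one from compound 1 to compound 3, and it was within the scatter; the step to compound 2, which brought the lower number, altered the whole amine group rather than just a substituent on it. A step of no size beyond the scatter is therefore expected, a 1.1-fold lower number from compound 3 to compound 4 (0.03 log units; within the scatter). Compound 4 is estimated at 60000 nM, between 20000 nM and 120000 nM.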

Compound 4, half-maximal cytotoxic concentration: 48000 nM
Beside the measured number, compound 4's estimate is 1.3-fold (0.10 log units) above it; low and high end bracket the measured number.
By their numbers in this assay, from the lowest: compound 2; then compounds 4 and 3 (each within the scatter of the next). At a limit, above all of these: compound 1.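

In this assay, going from methylamino to dimethylamino gave a 1.4-fold lower number from compound 3 to compound 4 (0.13 log units; within the scatter), so replacing the remaining hydrogen on this nitrogen with methyl did not move the read-out beyond the scatter. The dimethylamino group also left a 3.0-fold higher number from compound 2 to compound 4 (0.48 log units; beyond the scatter), so the lower number of compound 2 stands apart from both small amines, and the comparison with cyclopropylamino gave an at least 2.0-fold lower number from compound 1 to compound 4 (0.31 log units; beyond the scatter). That comparison rests on compound 1, whose value is a limit of the assay and not a number: the limit of > 100000 nM in this assay, at which 1 of the 4 values shown sits.

From the compounds shown here alone, it remains open whether longer chains on this nitrogen, as in diethylamino, would give numbers like that of compound 4. Going by these compounds, it is also open whether a piperidin-1-yl or morpholin-4-yl group would give a number like that of compound 2.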